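Methoxy on the Aryl Ketone of a Boron-Containing Chalcone

The compounds below may be only part of what the source reports. "The series", "measured", "known", "first", "only" and "open" are said of these compounds alone.

Measured compounds:
- Compound 1 `O=C(/C=C/c1ccc2c(c1)B(O)OC2)c1ccccc1` gives 3400 nM in a functional assay on SK-OV-3 cells (Homo sapiens) for cytotoxicity, read by MTT assay, with a stated time of 48 h; on this read-out lower numbers stand for stronger inhibition and higher numbers for weaker inhibition.
- Compound 2 `O=C(/C=C/c1ccc2c(c1)B(O)OC2)c1ccc(I)cc1` gives 4200 nM in this assay.
- Compound 3 `O=C(/C=C/c1ccc2c(c1)B(O)OC2)c1ccc(C(F)(F)F)cc1` gives 3700 nM in this assay.

The three compounds share one core and differ only in a substituent on the ring attached to the carbonyl. Compound 1, which carries no substituent there, shows the smallest number of the three on paper, but the steps of a 1.2-fold higher number from compound 1 to compound 2 (0.09 log units; within the scatter) and a 1.1-fold higher number from compound 1 to compound 3 (0.04 log units; within the scatter) are both within the scatter, so the three compounds cannot be told apart on this read-out.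

Compound 4 `COc1ccccc1C(=O)/C=C/c1ccc2c(c1)B(O)OC2` is the next member: methoxy in place of hydrogen on an aromatic carbon. Both earlier steps, iodo and trifluoromethyl in place of hydrogen on an aromatic carbon of that ring, left the number essentially unchanged, and the step between them, a 1.1-fold lower number from compound 2 to compound 3 (0.06 log units; within the scatter), was likewise within the scatter. Methoxy sits at a different place on the ring, so the earlier steps bear only loosely on it, and nothing in the data points in either direction. A step of a 1.0-fold higher number from compound 1 to compound 4 (0.01 log units; within the scatter) is therefore expected, that is, none beyond the scatter. Compound 4 is estimated at 3500 nM in this assay, with a range from 1700 nM to 7500 nM.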

Compound 4, half-maximal inhibitory concentration: 2600 nM
Beside the measured number, compound 4's estimate is 1.3-fold (0.13 log units) above it; the range from low to high includes it.
By their numbers in this assay, from the lowest: compounds 4, 1, 3 and 2 (each within the scatter of the next).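

Methoxy in place of hydrogen gives a 1.3-fold lower number from compound 1 to compound 4 (0.12 log units; within the scatter) in this assay and so, like the earlier changes, cannot be told apart from no change. The earlier compounds shown here showed this only for iodo and trifluoromethyl, whereas compound 4 extends it to a different group on an aromatic carbon ortho to a large group. No evidence is available on why the number stays within the scatter at this position.

Going by these compounds, it remains open whether an amine or a carboxylic acid on this same carbon would move the number beyond the scatter of repeated measurements. On these data alone, it also remains open whether methoxy on another carbon of this ring would leave the number just as unchanged.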